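Adding a Chain Back onto the Ring Nitrogen: Compound 4

The compounds below may be only part of what the source reports. "The series", "measured", "known", "first", "only" and "open" are said of these compounds alone.

Measured so far:
compound 1, `CCOC(CCn1c(Cc2nn(C)c(=O)c3ccccc23)nnc1SCCCCCCCC(=O)Nc1ccc(Cl)cc1Cl)OCC`, giving 16400 nM in an assay on 32D cells for inhibition of interleukin-15 (Mus musculus), read by resazurin assay, with stated times of 30 min and 2.5 days, in the presence of a further agent that is not named here; a higher number here means a weaker inhibitor, a lower number a stronger inhibitor
compound 2, `Cn1nc(Cc2nnc(SCCCCCCCC(=O)Nc3ccc(Cl)cc3Cl)n2CCC=O)c2ccccc2c1=O`, giving 5500 nM
compound 3, `Cn1nc(Cc2nnc(SCCCCCCCC(=O)Nc3ccc(Cl)cc3Cl)[nH]2)c2ccccc2c1=O`, giving 3500 nM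

Compound 3, which carries only hydrogen on the ring nitrogen, shows the lowest number of the three. The gap to compound 2 is small, a 1.6-fold lower number from compound 2 to compound 3 (0.20 log units; within the scatter), so these two cannot be ranked against each other. The gap to compound 1 is larger and clear, a 4.7-fold lower number from compound 1 to compound 3 (0.67 log units; beyond the scatter).

Compound 4, `CN(C)CCCn1c(Cc2nn(C)c(=O)c3ccccc23)nnc1SCCCCCCCC(=O)Nc1ccc(Cl)cc1Cl`, returns to a substituted ring nitrogen: 3-(dimethylamino)propyl in place of hydrogen on an aromatic nitrogen. Within the data shown here, two measured steps bear on this change, both running the other way, from a chain on that nitrogen to hydrogen: a 4.7-fold lower number from compound 1 to compound 3 (0.67 log units; beyond the scatter) and a 1.6-fold lower number from compound 2 to compound 3 (0.20 log units; within the scatter). One is modest, one is within the scatter, and both point to the chain-bearing compound showing the higher number. Compound 4 carries a chain of similar length to those of compound 1 and compound 2, though ending in a different group, so a modest rise is expected, a 2.0-fold higher number from compound 3 to compound 4 (0.30 log units; within the scatter). Compound 4 is therefore estimated at 7000 nM, with a likely range from 2500 nM to 20000 nM.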

Compound 4, half-maximal inhibitory concentration: 5500 nM
Compound 4: middle estimate off by 1.3-fold (0.10 log units), on the high side; the measured number falls inside the stated range.
By their numbers in this assay, from the lowest: compounds 3, 2 and 4 (each within the scatter of the next); then compound 1.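

In this assay the step to a chain ending in a dimethylamino group can't be told from the scatter (a 1.6-fold higher number from compound 3 to compound 4 (0.20 log units; within the scatter)), so bearing 3-(dimethylamino)propyl on this aromatic nitrogen, with its 6 heavy atoms, leaves the number indistinguishable from that of the bare nitrogen. This separates the chain from what sits at its end: compound 4 and compound 2 cannot be told apart (no change at the digits printed from compound 2 to compound 4 (within the scatter)), while the step from the diethoxymethyl end group is clear, though modest (a 3.0-fold lower number from compound 1 to compound 4 (0.47 log units; beyond the scatter)), so among these four compounds, compound 1 alone stands apart, and the chain itself does not go with a higher number in the other two chain-bearing compounds. No measurement offered here explains this result.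

The compounds shown leave open whether a carboxylic acid or a morpholine ring at the end of the chain, or a longer chain on the same nitrogen, would move the number beyond the scatter in either direction. They also leave open whether any group at this position can give a number clearly lower than that of compound 3 (3500 nM).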